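A few compounds are considered here, and "the series" means these few. Any claim that something is new, unique, unknown or untested is made for them only; others in the source may bear on it.

Compound 1, with the structure `CCCCCCOP(=O)(O)OCCSC(=S)N1CCCCCC1`, is the starting point. In a functional assay on DU-145 cells (Homo sapiens) for inhibition, read by MTT assay, with stated times of 18 h and 4 h (on this read-out lower numbers stand for stronger inhibition and higher numbers for weaker inhibition), compound 1 gives 77400 nM. Compound 3, `CCCOP(=O)(O)OCCSC(=S)N1CCCCCC1`, carries the change (hydrogen in place of propyl on a saturated chain carbon, three bonds along the chain from an oxygen on an unsaturated carbon). In this assay compound 3 gives 86100 nM, so the change produced a 1.1-fold higher number from compound 1 to compound 3 (0.05 log units; within the scatter), a step that is too small to separate the two compounds.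

Compound 2, `CCCCCCOP(=O)(O)OCCSC(=S)N1CCN(C)CC1`, differs from compound 1 in the core, by the change (4-methylpiperazin-1-yl in place of azepan-1-yl on a thiocarbonyl carbon). For compound 2, this assay reports only a limit, > 100000 nM, and not a number. This is the limit of > 100000 nM in this assay, at which 1 of the 3 values shown sits. The step from compound 1 to compound 2 therefore reads as an at least 1.2-fold higher number from compound 1 to compound 2 (0.11 log units; that floor lies within the scatter), a floor rather than a measured distance.

Compound 4, `CCCOP(=O)(O)OCCSC(=S)N1CCN(C)CC1`, has not been measured. It stands to compound 2 as compound 3 stands to compound 1: the change hydrogen in place of propyl on a saturated chain carbon, three bonds along the chain from an oxygen on an unsaturated carbon is the same change, made at the same place, on the core of compound 2 instead of the core of compound 1. For the measured compounds named here, the only guide is the step from compound 1 to compound 3, which was close to nothing, and the fact that compound 2 already sits at the limit of this assay. On that basis the step from compound 2 to compound 4 in this assay is expected to be about a step that the limit leaves unreadable from compound 2 to compound 4, again small. Compound 4 is therefore estimated to give 150000 nM, most likely reported as a limit, with a range from 80000 nM to 400000 nM.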

Compound 4, half-maximal inhibitory concentration: > 100000 nM
Compound 4 was reported as a limit (the forecaster's own chance of this, stated with the estimate: 75%); the middle value does not contradict the limit.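

Compound 2 and compound 4 are both reported only as limits in this assay, so no step between them can be read: the limit of > 100000 nM in this assay, at which 2 of the 4 values shown sit.

As far as these compounds go, what stays open is where the true values of compound 2 and compound 4 lie, and whether going from hexyl to propyl acts on the core of compound 2 as it does on the core of compound 1.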